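The source may hold more compounds than are shown below. What is called first, only, known or untested is meant among the compounds shown, and "the series" means these compounds.

In an in vitro ADME assay on microsomes (Rattus norvegicus) for metabolic stability (a higher number here means faster removal of the compound, a lower number slower removal), compound 1 `CC1CN(CC(=O)Nc2ccc(-n3ccccc3=O)cc2F)CC1NC(=O)c1ccc(Cl)s1` gives 166 mL.min-1.g-1 and compound 2 `O=C(CN1CC(NC(=O)c2ccc(Cl)s2)C(C2CC2)C1)Nc1ccc(-n2ccccc2=O)cc1F` gives 109 mL.min-1.g-1 as its number. Compound 3 `O=C(CN1C[C@H](NC(=O)c2ccc(Cl)s2)C[C@H]1CO)Nc1ccc(-n2ccccc2=O)cc1F` has the lowest of the three numbers at 17.6 mL.min-1.g-1 and lies well under both others. The move to compound 4 `O=C(CN1C[C@H](NC(=O)c2ccc(Cl)s2)C[C@H]1CN1CCCC1)Nc1ccc(-n2ccccc2=O)cc1F` is pyrrolidin-1-yl in place of hydroxy on a saturated chain carbon bound to a saturated ring carbon and reads as pyrrolidin-1-yl in place of hydroxy on a saturated chain carbon bound to a saturated ring carbon. For the measured compounds named here, no measured step covers this change. Going by the values given here, the only measured step is a 1.5-fold lower number from compound 1 to compound 2 (0.18 log units; within the scatter) for cyclopropyl in place of methyl on a saturated ring carbon, a different change that gives no size to carry over. Only compound 3 carries hydroxy, although it also differs from the other two elsewhere. With compound 1 at 166 mL.min-1.g-1 and compound 2 at 109 mL.min-1.g-1 without hydroxy, a rise beyond the scatter is expected, on thin evidence. The estimated step is a 3.4-fold higher number from compound 3 to compound 4 (0.53 log units; beyond the scatter) in this assay. Compound 4 is expected at about 60 mL.min-1.g-1 (estimated range 20 mL.min-1.g-1 to 170 mL.min-1.g-1).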

Compound 4, intrinsic clearance in microsomes: 116 mL.min-1.g-1
Beside the measured number, compound 4's estimate is 1.9-fold (0.29 log units) below it; the measured number falls inside the stated range.
By their numbers in this assay, from the lowest: compound 3; then compounds 2, 4 and 1 (each within the scatter of the next).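

In this assay, for the compounds shown here, pyrrolidin-1-yl in place of hydroxy on a saturated chain carbon bound to a saturated ring carbon gives a 6.6-fold higher number from compound 3 to compound 4 (0.82 log units; beyond the scatter), the only measured change at this place. Going by these compounds alone, the two compounds differ nowhere else, so the low number of compound 3 does not carry over to every group at this place, which the earlier comparisons could not show. The data give no reason for the rise.

From the compounds shown here alone, it remains open whether the rise goes with the ring of pyrrolidin-1-yl, with its nitrogen, or with the loss of hydroxy alone; a methoxy group, a dimethylamino group or a primary amine at the same place would help separate these. Going by these compounds, whether the same exchange gives a similar step on other members also remains open.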